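Methyl on the Furan Ring Within a Weakly Active Series

The source may report more compounds than this note shows. Statements on the series, on what has been measured and on what is new or still open speak of the compounds shown alone.

Compound 1 `Nc1nc(-c2ccco2)nc2sc(-c3ccccc3)nc12` was tested in a functional assay on CHO cells for antagonist activity at adenosine receptor A2b (Homo sapiens), read by cAMP accumulation, with a stated time of 10 min; on this read-out lower numbers stand for stronger inhibition and higher numbers for weaker inhibition. For compound 1 the read-out stops at a limit of the assay, > 30000 nM. Compound 2 `Cc1ccc(-c2nc(N)c3nc(-c4ccccc4)sc3n2)o1` differs from compound 1 by methyl in place of hydrogen on an aromatic carbon. For compound 2 the assay again reports only a limit, > 30000 nM. The step that the two limits leave unreadable from compound 1 to compound 2 therefore cannot be sized because of the limit of > 30000 nM in this assay, at which 3 of the 3 values shown sit. Compound 3 `Nc1nc(-c2ccco2)nc2sc(-c3ccco3)nc12` carries a different core; the two cores differ by furan-2-yl in place of phenyl on an aromatic carbon. For compound 3 the result is once more a limit, > 30000 nM. So a step that the two limits leave unreadable from compound 1 to compound 3 is unreadable as well. Compound 4 `Cc1ccc(-c2nc(N)c3nc(-c4ccco4)sc3n2)o1` differs from compound 3 by methyl in place of hydrogen on an aromatic carbon, the same change made from compound 1 to compound 2. The step is expected to be about a step that the limit leaves unreadable from compound 3 to compound 4, resting on (the limit of > 30000 nM in this assay, at which 3 of the 3 values shown sit). Compound 4 is expected to give roughly 40000 nM, probably between 10000 nM and 150000 nM.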

Compound 4, half-maximal inhibitory concentration: > 30000 nM
Compound 4: only a limit was reported (the forecaster's own chance of this, stated with the estimate: 85%); the middle value is on the limit's open side.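

Among the compounds shown here, compound 4 returns only a limit, so no step from compound 2 or compound 3 to compound 4 can be read: the limit of > 30000 nM in this assay, at which 4 of the 4 values shown sit. Whether methyl or furan-2-yl changes inhibition at all stays open, as no compound shown gives a number.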